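Dropping one allyl group from compound 1

The source may hold more compounds than are shown below. What is called first, only, known or untested is meant among the compounds shown, and "the series" means these compounds.

Of the compounds shown here, three have so far been tested in a functional assay on HUVEC cells (Homo sapiens) for antiproliferative activity, read by MTT assay, with a stated time of 24 h; on this read-out lower numbers stand for stronger inhibition and higher numbers for weaker inhibition. Compound 1, `C=CCc1cc(-c2ccc(OC)cc2)cc(CC=C)c1O`, gives > 100000 nM in this assay, and this is a limit of the assay rather than a measured number. Compound 2, `C=CCc1cc(-c2cccc([N+](=O)[O-])c2)cc(CC=C)c1O`, gives > 100000 nM in this assay, again a limit. Compound 3, `C=CCc1cc(-c2cccc([N+](=O)[O-])c2)ccc1OC`, gives > 100000 nM in this assay, also a limit. Compound 1 therefore stands exactly where the whole set stands: the limit of > 100000 nM in this assay, at which 3 of the 3 values shown sit. Among the compounds with values here, no two of these measured compounds differ in a single place, so no measured step is available to show what any one change does in this assay.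

Compound 4, `C=CCc1cc(-c2ccc(OC)cc2)ccc1O`, differs from compound 1 by hydrogen in place of allyl on an aromatic carbon. With every measured value sitting at the same limit, there is nothing in the data to suggest that this change moves the read-out one way or the other, and the account expects no step beyond the usual scatter. Compound 4 is therefore expected to give about 150000 nM in this assay, within a range of 40000 nM to 500000 nM, most likely reported again only as a limit. The step that the limit leaves unreadable from compound 1 to compound 4 that this estimate implies is expected to be negligible.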

Compound 4, half-maximal inhibitory concentration: > 100000 nM
Compound 4 ended at the assay's limit; the forecaster's own chance of this, stated with the estimate: 80%; the middle value does not contradict the limit.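

In this assay compound 4 gives > 100000 nM, which is a limit and not a number. Compound 1 also stands only at a limit, so no step can be read between compound 1 and compound 4. The set stands at one place: the limit of > 100000 nM in this assay, at which 4 of the 4 values shown sit.

The compounds shown leave open whether any change to the shared core gives a measurable value.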